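A few compounds are considered here, and "the series" means these few. Any claim that something is new, unique, unknown or untested is made for them only; others in the source may bear on it.

Measured compounds:

Compound 1, `C/N=C(\S)NCCCCn1nc(C)ccc1=O`: in a functional assay on the whole organism (stomach) with Rattus norvegicus as the target (a lower number here means that less compound is needed, a higher number that more compound is needed for the effect), compound 1 gives > 100 mg/kg, a limit of the assay and not a number.
Compound 2, `C/N=C(/NC#N)NCCCn1nc(-c2ccccc2)ccc1=O`: in this assay compound 2 gives > 100 mg/kg, again only a limit.
Compound 3, `O=c1ccc(-c2ccccc2)nn1CCCCNC(=S)Nc1ccc(Cl)cc1`: in this assay compound 3 gives > 100 mg/kg, also a limit.

Among the compounds with values here, compound 2 therefore stands nowhere above or below the others on the numbers at hand; every value is a limit, (the limit of > 100 mg/kg in this assay, at which 3 of the 3 values shown sit), and no measured step between any two compounds can be drawn. Compound 4, `C/N=C(\S)NCCCCCn1nc(-c2ccccc2)ccc1=O`, is not yet measured. It differs from compound 2 by a group of 7 heavy atoms (4 carbon, 2 nitrogen, 1 sulfur; no ring) in place of a group of 7 heavy atoms (3 carbon, 4 nitrogen; no ring), on a saturated chain carbon, three bonds along the chain from an aromatic nitrogen. The group that enters is the same kind of group that compound 1 carries, and compound 1 sits at the limit with > 100 mg/kg. With nothing in the series beyond the limit to lean on, no step beyond the usual scatter is expected, and the estimated change from compound 2 to compound 4 in this assay is a step that the limit leaves unreadable from compound 2 to compound 4. For compound 4 the expected dose is 120 mg/kg, estimated to lie between 30 mg/kg and 400 mg/kg, most likely reported again as a limit.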

Compound 4, dose for half-maximal effect: 35.3 mg/kg
Beside the measured number, compound 4's estimate is 3.4-fold (0.53 log units) above it; measured number inside the range.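

In this assay the exchange on a saturated chain carbon, three bonds along the chain from an aromatic nitrogen, gives an at least 2.8-fold lower number from compound 2 to compound 4 (0.45 log units; beyond the scatter) and so lies beyond the scatter. Within the data shown here, this is the first sign that the read-out responds to a change at this position, as compound 4 gives 35.3 mg/kg. The earlier compounds could show no such response, and every other step in the series cannot be read: the limit of > 100 mg/kg in this assay, at which 3 of the 4 values shown sit.

From the compounds shown here alone, the step is only a bound, so its true size stays open, and the exchanged group differs in both its sulfur and its nitrogen count, so no single part of it can be credited with the gain. Going by these compounds, whether a longer chain or a terminal amine in place of the entering group would lower the dose further also stays open.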